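The source may hold more compounds than are shown below. What is called first, only, known or untested is meant among the compounds shown, and "the series" means these compounds.

Measured so far:
compound 1 `O=C1O/C(=C\Cn2cc(C3=CCCCC3)nn2)C(OCc2ccccc2)=C1OCc1ccccc1` — 55600 nM
compound 2 `CC(C)(C)c1ccc(-c2cn(CCC3(O)NC(=O)C(OCc4ccccc4)=C3OCc3ccccc3)nn2)cc1` — 43000 nM

In a functional assay on PC-3 cells (Homo sapiens) for antiproliferative activity, read by MTT assay, with a stated time of 24 h (on this read-out higher numbers stand for weaker inhibition and lower numbers for stronger inhibition), compound 1 gives 55600 nM, the higher of the two numbers, though compound 2 lies within the scatter of it, so no order between them can be read. Compound 3 `O=C1O/C(=C\Cn2cc(-c3ccccn3)nn2)C(OCc2ccccc2)=C1OCc1ccccc1` differs from compound 1 in one place: pyridin-2-yl in place of cyclohex-1-en-1-yl on an aromatic carbon. Among the compounds with values here, no measured pair shows this change. Both known numbers sit at the weak end, and a change of this kind is expected to move the number little, in no clear direction and not beyond the scatter. Compound 3 is estimated at 50000 nM (range 15000 nM to 150000 nM), meaning an expected step of a 1.1-fold lower number from compound 1 to compound 3 (0.05 log units; within the scatter).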

Compound 3, half-maximal inhibitory concentration: > 100000 nM
Compound 3: a limit, no number (the forecaster's own chance of this, stated with the estimate: 10%); middle value at least 2.0-fold (0.30 log units) from the limit.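

In this assay compound 3 reads > 100000 nM, a limit of the assay and not a number. As far as these compounds go, at this aromatic carbon, pyridin-2-yl in place of cyclohex-1-en-1-yl gives an at least 1.7-fold higher number from compound 1 to compound 3 (0.25 log units; that floor lies within the scatter), so this first change at the position brings no sign of stronger inhibition, while the true size of the step stays unknown. The limit also marks the top of the readable range in this small set: the limit of > 100000 nM in this assay, at which 1 of the 3 values shown sits.

Still open, from the compounds shown here alone, is how far compound 3 lies past its limit. Also open, going by these compounds, is whether an amine or a carboxylic acid at this carbon would give stronger inhibition.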